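Amide substituent series at the 2-oxoglutarate receptor

The source may report more compounds than this note shows. Statements on the series, on what has been measured and on what is new or still open speak of the compounds shown alone.

Measured compounds:
compound 1 `CCCCCNC(=O)[C@H]1O[C@@H](n2cnc3c(N)ncnc32)[C@H](O)[C@@H]1O` gives 12 nM in an assay on cell membranes for binding affinity to 2-oxoglutarate receptor 1 (Rattus norvegicus), read by radioligand binding; a lower number here means a stronger inhibitor, a higher number a weaker inhibitor;
compound 2 `CC(C)(C)NC(=O)[C@H]1O[C@@H](n2cnc3c(N)ncnc32)[C@H](O)[C@@H]1O` gives 6850 nM;
compound 3 `Nc1ncnc2c1ncn2[C@@H]1O[C@H](C(=O)NC2CCCCC2)[C@@H](O)[C@H]1O` gives 18 nM.

Compound 3 sits with compound 1 at the strong end of this assay, the pair being separated only by a 1.5-fold higher number from compound 1 to compound 3 (0.18 log units; within the scatter), and far from compound 2, as a 380-fold lower number from compound 2 to compound 3 (2.58 log units; beyond the scatter) shows. Compound 4 `C[C@H]1CC[C@@H](NC(=O)[C@H]2O[C@@H](n3cnc4c(N)ncnc43)[C@H](O)[C@@H]2O)CC1` differs from compound 3 by methyl in place of hydrogen on a saturated ring carbon: cyclohexyl becomes 4-methylcyclohexyl, the methyl entering three ring bonds from the ring atom that bears the large group.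

The measured steps bear on this only indirectly. The pentyl to cyclohexyl exchange, a 1.5-fold higher number from compound 1 to compound 3 (0.18 log units; within the scatter), stayed within the scatter, so the assay tolerates a change of shape at the amide nitrogen; the branched tert-butyl, a 570-fold higher number from compound 1 to compound 2 (2.76 log units; beyond the scatter), was the one large loss, and a remote methyl on the ring does not resemble that change. The expectation for compound 4 is therefore a step of a 1.2-fold higher number from compound 3 to compound 4 (0.09 log units; within the scatter), no larger than the scatter, in either direction. Compound 4 is estimated at 22 nM, with a range from 8 nM to 65 nM.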

Compound 4, inhibition constant: 55.6 nM
Compound 4: the middle estimate sits 2.5-fold (0.40 log units) below what was measured; the measured number falls inside the stated range.
By their numbers in this assay, from the lowest: compounds 1 and 3 (each within the scatter of the next); then compound 4; then compound 2.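

In this assay, adding a single methyl on a saturated ring carbon, three ring bonds from the ring atom that bears the large group, is not silent (a 3.1-fold higher number from compound 3 to compound 4 (0.49 log units; beyond the scatter)): the step is modest but beyond the scatter. The 4-methylcyclohexyl amide also separates from the pentyl amide (a 4.6-fold higher number from compound 1 to compound 4 (0.67 log units; beyond the scatter)), a gap that cyclohexyl did not open, yet it remains well clear of the tert-butyl amide (a 120-fold lower number from compound 2 to compound 4 (2.09 log units; beyond the scatter)), so the large loss stays with tert-butyl alone among these compounds. Nothing available here gives a reason for these steps.

Going by these compounds, whether this step is specific to methyl remains open, since a hydroxyl, an amine or an ethyl on the same ring carbon would test that. On these data alone, the effect of the methyl at other carbons of the ring also remains open.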